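The compounds below may be only part of what the source reports. "The series", "measured", "known", "first", "only" and "open" are said of these compounds alone.

Measured in a functional assay on BGC-823 cells (Homo sapiens) for antiproliferative activity, read by MTT assay, tested at 5 uM; a higher number here means a stronger effect of the compound at the concentration tested, a lower number a weaker effect:
compound 1 `COc1cc(C(=O)N/N=C/c2ccc(F)c(F)c2)cc(OC)c1OC` gives 51.9%.
compound 2 `COc1cc(C2=NN(C(C)=O)C(c3ccccc3F)O2)cc(OC)c1OC` gives 32.8%.
compound 3 `COc1cc(C2=NN(C(C)=O)C(c3cccc(F)c3)O2)cc(OC)c1OC` gives 37.7%.

Compound 1 stands highest of the three numbers in this assay; compound 3 is nearest and compound 2 furthest, both beyond the scatter. Among the compounds with values here, the single measured step, a number 4.9 percentage points higher from compound 2 to compound 3 (within the scatter), concerns 3-fluorophenyl in place of 2-fluorophenyl on a saturated ring carbon of a different core and lies within the scatter; it does not touch the change now followed. The unmeasured compound 4 `COc1cc(C(=O)N/N=C/c2cc(Cl)cc(Cl)c2)cc(OC)c1OC` differs from compound 1 by 3,5-dichlorophenyl in place of 3,4-difluorophenyl on a carbon with a double bond to nitrogen. Within the data shown here, no measured step covers this exchange, so in this assay no step beyond the scatter is expected in either direction. Compound 4 is expected to give 50% in this assay. The expected range for compound 4 runs from 30% to 70%. This means an expected step of a number 1.9 percentage points lower from compound 1 to compound 4 (within the scatter).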

Compound 4, a percentage reported as inhibition, at one concentration (the size of the read-out at that concentration, not a potency): 9.2%
For compound 4 the middle estimate is 40.8 percentage points above the measured one; the whole stated range lies above it.
By their numbers in this assay, from the lowest: compound 4; then compounds 2 and 3 (each within the scatter of the next); then compound 1.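

In this assay, this carbon with a double bond to nitrogen does not tolerate every dihalophenyl group: 3,5-dichlorophenyl in place of 3,4-difluorophenyl gives a number 42.7 percentage points lower from compound 1 to compound 4 (beyond the scatter) for this exchange. The heavy-atom, ring and hydrogen-bond counts of the group are the same on both sides, so those counts do not track the result. Nothing available here bears on the cause of the step.

Within the data shown here, the single exchange changes both the halogen and its pattern on the ring, so 3,4-dichlorophenyl or 3,5-difluorophenyl would be needed to separate the two. Going by these compounds, how a phenyl ring carrying an amine or a carboxylic acid behaves at this position remains open.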